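This account rests on a few compounds, and the source may have more. Where it says the series, first, only, none or still open, it means among the compounds named here.

Measured compounds in a functional assay on MCF7 cells (Homo sapiens) for cytotoxicity, read by sulforhodamine B assay, with a stated time of 24 h; on this read-out lower numbers stand for stronger inhibition and higher numbers for weaker inhibition:
- compound 1 `O=C1Nc2ccc(S(=O)(=O)N3CCOCC3)cc2/C1=N/c1cccc(C(F)(F)F)c1`: 41100 nM
- compound 2 `CC(=O)c1cccc(/N=C2\C(=O)Nc3ccc(S(=O)(=O)N4CCOCC4)cc32)c1`: 39200 nM
- compound 3 `O=C1Nc2ccc(S(=O)(=O)N3CCOCC3)cc2/C1=N/c1ccc(Br)cc1`: 44800 nM

Compound 3 has the highest of the three numbers in this assay, but only just: its nearest neighbour is compound 1 a 1.1-fold higher number from compound 1 to compound 3 (0.04 log units; within the scatter) and its furthest is compound 2 a 1.1-fold higher number from compound 2 to compound 3 (0.06 log units; within the scatter). All three values lie within the scatter of one another, so no order among them can be read.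

Compound 4 `CC(=O)N/N=C1\C(=O)Nc2ccc(S(=O)(=O)N3CCOCC3)cc21` is the next structure. The change from compound 3: acetamido in place of 4-bromophenyl on a double-bonded nitrogen

The steps measured so far all exchange one aromatic substituent for another on the same double-bonded nitrogen: a 1.0-fold lower number from compound 1 to compound 2 (0.02 log units; within the scatter), a 1.1-fold higher number from compound 1 to compound 3 (0.04 log units; within the scatter) and a 1.1-fold higher number from compound 2 to compound 3 (0.06 log units; within the scatter). None of them moves beyond the scatter, and none removes the ring itself or introduces a hydrogen-bond donor and acceptor at that position, so they bear on the present step only loosely. The flat record argues for no large movement, but the change is of a different kind, so the expectation is kept wide: compound 4 is expected to show a 1.1-fold higher number from compound 3 to compound 4 (0.05 log units; within the scatter) in this assay. Compound 4 is estimated at 50000 nM, with a range from 18000 nM to 140000 nM.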

Compound 4, half-maximal inhibitory concentration: 56000 nM
Compound 4: the middle estimate sits 1.1-fold (0.05 log units) below what was measured; measured number inside the range.
By their numbers in this assay, from the lowest: compounds 2, 1, 3 and 4 (each within the scatter of the next).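

In this assay, acetamido on the double-bonded nitrogen, with no ring and with one hydrogen-bond donor and one acceptor, gives a 1.3-fold higher number from compound 3 to compound 4 (0.10 log units; within the scatter), alongside a 1.4-fold higher number from compound 2 to compound 4 (0.15 log units; within the scatter) and a 1.4-fold higher number from compound 1 to compound 4 (0.13 log units; within the scatter). The earlier steps shown here only exchanged one substituted phenyl group for another, whereas these show that even removing the aromatic ring at this position leaves all four compounds within the scatter of one another. No supporting measurement is available to explain this flat record.

From the compounds shown here alone, it remains open whether an amine, a carboxylic acid or a longer chain on this nitrogen would give a value beyond the scatter of these four. The compounds shown also share one core, so they say nothing about changes made elsewhere in it.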